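Carbamate variation on the shared core: efficacy notes

The source may report more compounds than this note shows. Statements on the series, on what has been measured and on what is new or still open speak of the compounds shown alone.

Three compounds of this series have numbers in a functional assay on CHO-K1 cells with Glucose-dependent insulinotropic receptor (Homo sapiens) as the target, read by a luciferase reporter, with a stated time of 5 h; on this read-out higher numbers stand for larger maximal responses and lower numbers for smaller maximal responses. Compound 1 `CC(C)(C)OC(=O)N1CCC(Oc2cccc3c2ccn3-c2ccc(S(C)(=O)=O)cc2)CC1` gives 28%. Compound 2 `CC(C)OC(=O)N1CCC(Oc2ncnc3c2CCN3c2ccc(C#N)cc2F)CC1` gives 134%. Compound 3 `COC(=O)N1CCC(Oc2ncnc3c2CCN3c2ccc(S(C)(=O)=O)cc2F)CC1` gives 119%, the second highest of the three; the nearest number is that of compound 2, which lies beyond the scatter above it, and the furthest is that of compound 1, far below and also beyond the scatter. Among the compounds with values here, no two of these three differ in one place only, so no single measured step exists within the set, and all three carry different carbamate groups as well as different cores and aryl substituents.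

Compound 4 `CSC(=O)N1CCC(Oc2ncnc3c2CCN3c2ccc(S(C)(=O)=O)cc2F)CC1` has not yet been measured. It differs from compound 3 in one place: methylsulfanyl in place of methoxy on a carbonyl carbon. Within the data shown here, no measured pair isolates a change of this kind at the carbonyl carbon, so the expectation rests on the level of compound 3 alone. The step of a number 7 percentage points lower from compound 3 to compound 4 (within the scatter) is expected to be small, most likely within the scatter, with no clear direction. Compound 4 is expected to give 112%, in a range from 85% to 140%.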

Compound 4, largest response reached (reported as percent of maximum), in percent of the reference or control that the assay uses: 135%
Compound 4: middle estimate off by 23 percentage points, on the low side; low and high end bracket the measured number.
By their numbers in this assay, from the lowest: compound 1; then compound 3; then compounds 2 and 4 (each within the scatter of the next).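

Methylsulfanyl in place of methoxy on a carbonyl carbon gives a number 16 percentage points higher from compound 3 to compound 4 (beyond the scatter) in this assay and is the first step in the series that isolates a change at this position. The position accepts sulfur in place of oxygen on the carbonyl carbon, and the maximal response stays high and moves up modestly rather than being lost. Nothing available bears on what lies behind this step.

This single pair leaves open whether the same exchange gives a similar step on the isopropyl carbamate of compound 2, or with other aryl substituents. Also open, going by these compounds, is how a longer chain such as ethylsulfanyl, or an amine such as dimethylamino, would read out on the same carbonyl carbon.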